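A few compounds are considered here, and "the series" means these few. Any claim that something is new, unique, unknown or untested is made for them only; others in the source may bear on it.

Measured compounds:
compound 1, `COc1ccc(-c2cc(O)c3c(C)cc(C)nc3n2)cc1`, 33100 nM
compound 2, `COc1ccccc1-c1cc(O)c2cccnc2n1`, 20000 nM
compound 3, `COc1ccccc1-c1cc(O)c2c(C)ccnc2n1`, 8320 nM

Three compounds sharing a related bicyclic core carrying a methoxyphenyl group were tested in a functional assay on MDA-N cells (Homo sapiens); a lower number here means a stronger inhibitor of growth, a higher number a weaker inhibitor of growth. Compound 3 gives 8320 nM, while compound 2 gives 20000 nM, and compound 1 gives 33100 nM. Compound 2 differs from compound 3 by hydrogen in place of methyl on an aromatic carbon, and that single change gives a 2.4-fold higher number from compound 3 to compound 2 (0.38 log units; beyond the scatter). The difference between the cores of compound 1 and compound 3 is not broken down here, and the values of compound 1 and compound 2 lie within the usual scatter of each other.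

The unmeasured compound 4, `COc1ccc(-c2cc(O)c3ccc(C)nc3n2)cc1`, differs from compound 1 by hydrogen in place of methyl on an aromatic carbon. This is the same kind of change as that from compound 3 to compound 2, though here the place is also meta to a methyl group. Because compound 3 to compound 2 gave a 2.4-fold higher number from compound 3 to compound 2 (0.38 log units; beyond the scatter), a step of similar size is expected from compound 1 to compound 4 in this assay, namely a 1.8-fold higher number from compound 1 to compound 4 (0.26 log units; within the scatter). Compound 4 is thus estimated at 60000 nM, expected to fall between 25000 nM and 150000 nM.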

Compound 4, concentration for 50% growth inhibition: 55000 nM
Compound 4: middle estimate off by 1.1-fold (0.04 log units), on the high side, within the range that was stated.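

In this assay hydrogen in place of methyl on the core of compound 1 gives a 1.7-fold higher number from compound 1 to compound 4 (0.22 log units; within the scatter) and so, taken alone, this step does not stand clear of the scatter. Set beside the earlier case, the two steps have the same direction and do not differ beyond the scatter: the same change on two cores in this assay, a 2.4-fold higher number (0.38 log units; beyond the scatter) from compound 3 to compound 2 and a 1.7-fold higher number (0.22 log units; within the scatter) from compound 1 to compound 4, 1.4-fold (0.16 log units) apart, within the scatter of two such steps. Among these compounds, this is consistent with the change carrying over between these two cores with a similar size, but it rests on only two pairs, one of them within the scatter, and it does not show that the step is real on the core of compound 1 or that it would hold on any further core.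

The compounds shown leave open what a longer chain, a chlorine atom or an amine would do in place of the methyl on this aromatic carbon. They also leave open whether the step would look the same in any other cell line.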